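Hydroxymethyl to Methoxy: What to Expect for Compound 3

The source may report more compounds than this note shows. Statements on the series, on what has been measured and on what is new or still open speak of the compounds shown alone.

Of the compounds shown here, two sharing one core have been measured. Compound 1 `O=C(SCCc1ccc(O)cc1)SCc1ccc(Cl)cc1Cl` carries a hydroxy group on an aromatic carbon; in an assay on tissue (A-431 cells) for inhibition of Indoleamine 2,3-dioxygenase 1 (Homo sapiens), with a stated time of 24 h (a higher number here means a weaker inhibitor, a lower number a stronger inhibitor), compound 1 gives 400 nM. Compound 2 `O=C(SCCc1ccc(CO)cc1)SCc1ccc(Cl)cc1Cl` carries a hydroxymethyl group there instead, and in this assay compound 2 gives 270 nM. The step of a 1.5-fold lower number from compound 1 to compound 2 (0.17 log units; within the scatter) is within the scatter, so compound 2 stands at the low end of the two numbers without being set apart from compound 1 in any reliable way.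

Compound 3 `COc1ccc(CCSC(=O)SCc2ccc(Cl)cc2Cl)cc1` has not yet been measured. It differs from compound 2 in one place: methoxy in place of hydroxymethyl on an aromatic carbon. For the measured compounds named here, no measured step exchanges hydroxymethyl for methoxy; the only step on record, a 1.5-fold lower number from compound 1 to compound 2 (0.17 log units; within the scatter), bears on it just indirectly, showing that changing the group on this aromatic carbon from hydroxy to hydroxymethyl left the number within the scatter. On that basis the expected step of a 1.1-fold higher number from compound 2 to compound 3 (0.05 log units; within the scatter) is small, with no direction beyond the scatter. Compound 3 is therefore estimated at 300 nM in this assay, with a range from 120 nM to 800 nM.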

Compound 3, half-maximal inhibitory concentration: 270 nM
Beside the measured number, compound 3's estimate is 1.1-fold (0.05 log units) above it; the measured number falls inside the stated range.
By their numbers in this assay, from the lowest: compounds 2, 3 and 1 (each within the scatter of the next).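

In this assay, the exchange of hydroxymethyl for methoxy on this aromatic carbon, para to a large group, gives no change at the digits printed from compound 2 to compound 3 (within the scatter). For the compounds shown here, this is the first direct reading of that change: the two groups have the same atoms joined differently, and the hydrogen-bond donor of hydroxymethyl is absent from methoxy, yet the numbers do not separate. Methyl in place of hydrogen on the oxygen on the aromatic ring gives a 1.5-fold lower number from compound 1 to compound 3 (0.17 log units; within the scatter), so hydroxy, hydroxymethyl and methoxy cannot be told apart at this position in this assay, and no evidence is available to explain why these three groups read alike.

From the compounds shown here alone, all three groups contain oxygen, so it remains open whether an amine, a carboxylic acid or a longer chain such as ethoxy on this aromatic carbon would also stay within the scatter. The rest of the shared core is the same in all three compounds, so they give no reading of how a change elsewhere would affect the number.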